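The source may hold more compounds than are shown below. What is called first, only, known or untested is meant among the compounds shown, and "the series" means these compounds.

Measured in a functional assay on DU-145 cells (Homo sapiens) for cytotoxicity, read by trypan blue exclusion, with a stated time of 96 h; on this read-out higher numbers stand for weaker inhibition and lower numbers for stronger inhibition:
- compound 1 `COc1ccc(NS(=O)(=O)/C=C/c2ccccc2OC)cc1`: 5000 nM
- compound 2 `COc1ccc(NS(=O)(=O)/C=C/c2c(OC)cccc2OC)cc1`: 375 nM

Compound 2, at 375 nM, holds the lower of the two numbers. Compound 3 `COc1ccc(NS(=O)(=O)/C=C/c2c(OC)cc(O)cc2OC)cc1` differs from it by hydroxy in place of hydrogen on an aromatic carbon, meta to two methoxy groups and para to a large group (hydroxy in place of hydrogen on an aromatic carbon). Going by the values given here, the only measured step, a 13-fold lower number from compound 1 to compound 2 (1.12 log units; beyond the scatter), was large, but it involved methoxy rather than hydroxy, so it bears on this change only loosely. A smaller move in the same direction is expected, with a 1.9-fold lower number from compound 2 to compound 3 (0.27 log units; within the scatter) as the estimated step. Compound 3 is estimated at 200 nM, with an expected range of 30 nM to 1000 nM.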

Compound 3, half-maximal inhibitory concentration: 10000 nM
Compound 3: middle estimate off by 50-fold (1.70 log units), on the low side; measured number outside the range, above it.
By their numbers in this assay, from the lowest: compound 2; then compounds 1 and 3 (each within the scatter of the next).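

Adding hydroxy on the aromatic carbon para to a large group and meta to two methoxy groups gave a 27-fold higher number from compound 2 to compound 3 (1.43 log units; beyond the scatter), which means much weaker inhibition. Going by these compounds alone, the one earlier step, a methoxy added at another place, had moved the number the opposite way, so an added oxygen-bearing group on this ring does not lower the number in every case. Nothing measured here accounts for this change. Going by these compounds, whether any group on this carbon would do the same remains open. The compounds shown do not tell how a methoxy, an amine or a fluorine atom would behave there.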